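Dropping one trifluoromethyl from a urea-linked pyrazole inhibitor

A few compounds are considered here, and "the series" means these few. Any claim that something is new, unique, unknown or untested is made for them only; others in the source may bear on it.

Measured so far:
compound 1 `O=C(Nc1cccc(-n2cc(-c3ccncc3)c(-c3cc(O)cc(Cl)c3)n2)c1)Nc1ccc(Cl)c(C(F)(F)F)c1`, 57%
compound 2 `O=C(Nc1cccc(-n2cc(-c3ccncc3)c(-c3cc(O)cc(Cl)c3)n2)c1)Nc1ccc(Cl)c(Cl)c1`, 62%
compound 3 `COc1cc(Cl)cc(-c2nn(-c3cccc(NC(=O)Nc4cc(C(F)(F)F)cc(C(F)(F)F)c4)c3)cc2-c2ccncc2)c1`, 28%

In a functional assay on SR cells (Homo sapiens) for inhibition, read by sulforhodamine B assay, with a stated time of 48 h, tested at 1 uM (a higher number here means a weaker effect of the compound at the concentration tested, a lower number a stronger effect), compound 3 gives the lowest number of the three, so it shows the strongest effect here: compound 1 is higher by a margin beyond the scatter, and compound 2 higher still. Compound 1 and compound 2 differ only in one spot, and that step, a number 5 percentage points higher from compound 1 to compound 2 (within the scatter), stays within the scatter.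

Compound 4 `COc1cc(Cl)cc(-c2nn(-c3cccc(NC(=O)Nc4cccc(C(F)(F)F)c4)c3)cc2-c2ccncc2)c1` comes from compound 3 by a single change: hydrogen in place of trifluoromethyl on an aromatic carbon. Among the compounds with values here, no measured step shows this same change; the one step that exists swaps a chloro for a trifluoromethyl, not a hydrogen, and it was small. So the expectation rests on the change itself. Removing one of the two trifluoromethyl groups takes compound 4 part of the way toward the smaller substitution seen on compound 1 and compound 2, which give higher numbers than compound 3. Compound 4 is therefore expected to give a higher number than compound 3, a step estimated at a number 17 percentage points higher from compound 3 to compound 4 (beyond the scatter), though a result within the scatter cannot be ruled out. The estimate for compound 4 in this assay is 45%, within a range of 25% to 68%.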

Compound 4, a percentage reported as activity, at one concentration (the size of the read-out at that concentration, not a potency): 55%
The estimate for compound 4 lay 10 percentage points below the measured number, within the range that was stated.
By their numbers in this assay, from the lowest: compound 3; then compounds 4, 1 and 2 (each within the scatter of the next).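

In this assay, putting hydrogen in place of one trifluoromethyl, at a place meta to a trifluoromethyl group, gives a number 27 percentage points higher from compound 3 to compound 4 (beyond the scatter). Within the data shown here, this is the first measured change at this position, and it shows that the group lost here counts: with the other trifluoromethyl left in place, the effect at the tested concentration is clearly weaker. Among these compounds, the only earlier step, chloro in place of trifluoromethyl, gave a number 5 percentage points higher from compound 1 to compound 2 (within the scatter), so this new step is also the first case in which a single swap on this ring moves the number by more than the usual scatter, though it rests on one pair of compounds and says nothing yet about other cores.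

The compounds shown leave open what other groups would do at this place, such as a methyl, a nitrile, an amine or a carboxylic acid, and whether any of them would keep the number near that of compound 3 or let it rise to that of compound 4. Nothing measured here tells why removing this trifluoromethyl changes the number by this much.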